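This account rests on a few compounds, and the source may have more. Where it says the series, first, only, none or still open, it means among the compounds named here.

Of the compounds shown here, two that share one core have been measured in an ADME assay on cells for inhibition of sodium channel protein type 1 subunit alpha (Homo sapiens), read by patch clamp, tested at 10 uM; on this read-out lower numbers stand for less inhibition and higher numbers for more inhibition at the one concentration tested (going by the name of the read-out). Compound 1 `O=C1c2cc(-c3ccc(OC(F)(F)F)cc3)ccc2OCCN1Cc1ncccn1` gives 53% in this assay. Compound 2 `O=C1c2cc(-c3ccc(OC(F)(F)F)cc3)ccc2CCN1Cc1ncccn1` gives 23% in this assay, the lower of the two numbers, and its gap to compound 1 lies beyond the usual scatter of repeated measurements. Compound 3 `O=C1c2cc(-c3ccc(C(F)(F)F)cc3)ccc2CCN1Cc1ncccn1` has not yet been measured in this assay. It differs from compound 2 in a single place: trifluoromethyl in place of trifluoromethoxy on an aromatic carbon. Among the compounds with values here, no measured pair shows what exactly this exchange does, so the expectation rests on compound 2 alone. Such a change is expected to move the number only a little in either direction, most likely not beyond the scatter, so the estimated step of a number 4 percentage points higher from compound 2 to compound 3 (within the scatter) is small. Compound 3 is therefore expected to give about 27% in this assay, within a range from 8% to 50%.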

Compound 3, a percentage reported as inhibition, at one concentration (the size of the read-out at that concentration, not a potency) in the sodium channel protein type 1 subunit alpha assay: 15%
Compound 3: the middle estimate sits 12 percentage points above what was measured; measured number inside the range.
By their numbers in the sodium channel protein type 1 subunit alpha assay, from the lowest: compounds 3 and 2 (each within the scatter of the next); then compound 1.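

In the sodium channel protein type 1 subunit alpha assay, putting trifluoromethyl in place of trifluoromethoxy on this aromatic carbon gives a number 8 percentage points lower from compound 2 to compound 3 (within the scatter), so at this position the two groups cannot be told apart by this read-out. In a physicochemical assay for solubility (a higher number here means a more soluble compound, a lower number a less soluble compound), compound 2 gives 60000 nM and compound 3 gives 28000 nM. The same exchange therefore does register in the physicochemical assay, although only modestly: the measured solubility of compound 2, 60000 nM, and of compound 3, 28000 nM, a 2.1-fold lower number (0.33 log units; beyond the scatter)

The compounds shown leave open whether other groups at this position, such as a nitrile, a methoxy group or a chlorine atom, would behave in the same way in either read-out. They also leave open whether the exchange of trifluoromethoxy for trifluoromethyl would give a similar result on the core of compound 1.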